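Nitro in Place of Bromo: Expecting Compound 4

The source may report more compounds than this note shows. Statements on the series, on what has been measured and on what is new or still open speak of the compounds shown alone.

Measured compounds in a functional assay on A549 cells (Homo sapiens) for cytotoxicity, read by MTT assay, with a stated time of 48 h; a lower number here means a stronger inhibitor, a higher number a weaker inhibitor:
- compound 1, `COc1cc(-c2nnc3n2NC(c2cccs2)C(C(=O)c2ccccc2)S3)cc(OC)c1OC`, gives 69400 nM
- compound 2, `COc1cc(-c2nnc3n2NC(c2cccs2)C(C(=O)c2ccc(F)cc2)S3)cc(OC)c1OC`, gives 45000 nM
- compound 3, `COc1cc(-c2nnc3n2NC(c2ccco2)C(C(=O)c2ccc(Br)cc2)S3)cc(OC)c1OC`, gives 42100 nM

Compound 3 has the lowest of the three numbers, yet its gaps to compound 2 and compound 1 are both within the scatter, so the three stand together. Compound 4, `COc1cc(-c2nnc3n2NC(c2ccco2)C(C(=O)c2ccc([N+](=O)[O-])cc2)S3)cc(OC)c1OC`, differs from compound 3 in one place: nitro in place of bromo on an aromatic carbon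

Going by the values given here, the only measured step on that same six-membered aromatic ring is a 1.5-fold lower number from compound 1 to compound 2 (0.19 log units; within the scatter), which stayed within the scatter. Among the compounds with values here, no measured step exchanges bromo for nitro. He therefore expects compound 4 to stay near compound 3, with a step of a 1.2-fold lower number from compound 3 to compound 4 (0.08 log units; within the scatter) in this assay, not beyond the scatter. His estimate for compound 4 is 35000 nM, ranging from 14000 nM to 90000 nM.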

Compound 4, half-maximal inhibitory concentration: > 100000 nM
Compound 4: only a limit was reported; the forecaster's own chance of this, stated with the estimate: 10%; at least 2.8-fold (0.45 log units) between middle value and limit.
By their numbers in this assay, from the lowest: compounds 3, 2 and 1 (each within the scatter of the next). At a limit, above all of these: compound 4.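

Nitro in place of bromo on this aromatic carbon, para to a large group, brought an at least 2.3-fold higher number from compound 3 to compound 4 (0.37 log units; beyond the scatter) in this assay. Going by these compounds alone, this is the first step to lie beyond the scatter, so this position does not tolerate every substituent equally. For compound 4 only a limit was reported, and the full size of the step cannot be read from it: the limit of > 100000 nM in this assay, at which 1 of the 4 values shown sits.

The compounds shown leave open whether an amine or a nitrile here would stay near compound 3. They also leave open whether nitro would act alike on the core of compound 2.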